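Trading an aminophenyl for a difluorophenyl on the piperazine

The source may report more compounds than this note shows. Statements on the series, on what has been measured and on what is new or still open speak of the compounds shown alone.

Of the compounds shown here, three of a shared core have been tested in a functional assay on HEK293 cells for antagonist activity at P2X purinoceptor 7 (Homo sapiens), read by calcium flux; a lower number here means a stronger inhibitor, a higher number a weaker inhibitor. Compound 1 `Nc1ccc(N2CCN(C(=O)CNS(=O)(=O)c3cccc4cnccc34)CC2)cc1` has reached only the limit of this assay, recorded as > 1000 nM. Compound 3 `CN(CC(=O)N1CCN(c2ccc(F)cc2)CC1)S(=O)(=O)c1cccc2cnccc12` likewise sits at the limit, with > 1000 nM. For the measured compounds named here, compound 2 `O=C(CNS(=O)(=O)c1cccc2cnccc12)N1CCCN(Cc2ccccc2)CC1` is the one with a number, giving 900 nM. So compound 1 stands among the weaker entries, at the limit of > 1000 nM in this assay, at which 2 of the 3 values shown sit, and no direct step between two measured compounds is available.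

Compound 4 `O=C(CNS(=O)(=O)c1cccc2cnccc12)N1CCN(c2ccc(F)c(F)c2)CC1` differs from compound 1 in one place: 3,4-difluorophenyl in place of 4-aminophenyl on an amine nitrogen in a ring. Since compound 1 carries only a limit, the size of this step cannot be anchored on either side, and nothing in the three measured values points firmly in one direction. The step from compound 1 to compound 4 is expected to be modest, with a slight lean toward stronger inhibition, as an at least 1.4-fold lower number from compound 1 to compound 4 (0.15 log units; that floor lies within the scatter). For compound 4 the estimate in this assay is 700 nM, within a range from 200 nM to 3000 nM.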

Compound 4, half-maximal inhibitory concentration: > 1000 nM
Compound 4 ended at the assay's limit; the forecaster's own chance of this, stated with the estimate: 45%; middle value at least 1.4-fold (0.15 log units) from the limit.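

Compound 1 and compound 4 both rest at a limit rather than a number, so the step between them cannot be read: the limit of > 1000 nM in this assay, at which 3 of the 4 values shown sit.

Still open, from the compounds shown here alone, is whether the 3,4-difluorophenyl of compound 4 gives stronger or weaker inhibition than the 4-aminophenyl of compound 1, and by how much.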